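Replacing nitro with hydroxy on the imine-linked aryl ring

The source may hold more compounds than are shown below. What is called first, only, known or untested is meant among the compounds shown, and "the series" means these compounds.

Of the compounds shown here, three sharing the same core have been tested in a functional assay on MDA-MB-231 cells (Homo sapiens) for antiproliferative activity, read by MTT assay, with a stated time of 48 h; on this read-out higher numbers stand for weaker inhibition and lower numbers for stronger inhibition. Compound 1 `COc1cc(/C=N/c2c(C#N)ncn2-c2ccc(F)cc2)cc(OC)c1OC` gives 18700 nM. Compound 2 `COc1ccc(OC)c(/C=N/c2c(C#N)ncn2-c2ccc(F)cc2)c1` gives 12300 nM. Compound 3 `N#Cc1ncn(-c2ccc(F)cc2)c1/N=C/c1ccc([N+](=O)[O-])cc1` gives 13400 nM. On these numbers compound 3 stands second highest of the three; its nearest neighbour is compound 2 and its furthest is compound 1, and both of those gaps lie within the usual scatter, so the three values cannot be told apart with confidence.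

Compound 4 `N#Cc1ncn(-c2ccc(F)cc2)c1/N=C/c1ccc(O)cc1` is the next compound, not yet measured. It differs from compound 3 in one place: hydroxy in place of nitro on an aromatic carbon. Among the measured compounds shown here, no pair of measured compounds in this set differs by a single change, so there is no measured step to lean on. With all three measured values sitting close together, a step in this assay beyond the scatter is not expected in either direction. For compound 4 the estimated value in this assay is 15000 nM, with a range from 6000 nM to 40000 nM. This corresponds to an expected step of a 1.1-fold higher number from compound 3 to compound 4 (0.05 log units; within the scatter).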

Compound 4, half-maximal inhibitory concentration: 16300 nM
Estimate against measurement, compound 4: 1.1-fold (0.04 log units) below; measured number inside the range.
By their numbers in this assay, from the lowest: compounds 2, 3, 4 and 1 (each within the scatter of the next).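

Among the compounds shown here, this is the first pair in the set that differs in a single place. In this assay, hydroxy in place of nitro on an aromatic carbon, para to a large group, gives a 1.2-fold higher number from compound 3 to compound 4 (0.09 log units; within the scatter), which lies within the scatter, so the two compounds cannot be told apart. At this position, nitro, with 3 heavy atoms and 0 hydrogen-bond donors, and hydroxy, with 1 heavy atom and 1 hydrogen-bond donor, therefore read alike, though no supporting measurement is available to explain that result.

This single pair cannot show whether other groups at this position would also read alike. An amine, a carboxylic acid or a longer chain such as ethoxy could stay within the scatter or move the number beyond it.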